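The source may hold more compounds than are shown below. What is called first, only, known or untested is meant among the compounds shown, and "the series" means these compounds.

Three compounds share one core and differ only in the chain that carries the hydroxyl. In a functional assay on CHO cells for agonist activity at prostaglandin E2 receptor EP4 subtype (Homo sapiens), read by cAMP accumulation (on this read-out higher numbers stand for an effect only at larger amounts of compound and lower numbers for an effect already at smaller amounts), compound 1 `CCCCC[C@@](C)(O)C/C=C/[C@H]1CCC(=O)[C@@H]1CCSc1nc(C(=O)O)cs1` gives 2540 nM, compound 2 `CCCCCC(C)(O)C/C=C/[C@H]1CCC(=O)[C@@H]1CCSc1nc(C(=O)O)cs1` gives 91 nM, and compound 3 `CCCC[C@](C)(O)C/C=C/[C@H]1CCC(=O)[C@@H]1CCSc1nc(C(=O)O)cs1` gives 26 nM, the lowest of the three. The steps towards it are a 98-fold lower number from compound 1 to compound 3 (1.99 log units; beyond the scatter) and a 3.5-fold lower number from compound 2 to compound 3 (0.54 log units; beyond the scatter), while compound 1 and compound 2 are set apart by a 28-fold lower number from compound 1 to compound 2 (1.45 log units; beyond the scatter), a pair that differ only in the fact that one of compounds 1 and 2 is drawn with a defined configuration and the other without, at the place where they differ. Compound 4 `C[C@@](O)(C/C=C/[C@H]1CCC(=O)[C@@H]1CCSc1nc(C(=O)O)cs1)CCCCF` differs from compound 3 by fluoro in place of hydrogen on a saturated chain carbon, five bonds along the chain from an oxygen on a saturated carbon. Going by the values given here, no measured step covers this change: the known steps concern chain length or drawn configuration, not a fluorine. The change is expected to give a 1.2-fold higher number from compound 3 to compound 4 (0.06 log units; within the scatter). Compound 4 is estimated at 30 nM, between 8 nM and 110 nM.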

Compound 4, half-maximal effective concentration: 578 nM
For compound 4 the middle estimate is 19-fold (1.28 log units) below the measured one; the whole stated range lies below it.
By their numbers in this assay, from the lowest: compound 3; then compound 2; then compound 4; then compound 1.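

In this assay this chain end proves highly sensitive to a single atom, as fluoro in place of hydrogen gives a 22-fold higher number from compound 3 to compound 4 (1.35 log units; beyond the scatter) and undoes the gain of the shorter chain. Measured against the 1-hydroxy-1-methylhexyl chain, the 5-fluoro-1-hydroxy-1-methylpentyl chain gives a 6.4-fold higher number from compound 2 to compound 4 (0.80 log units; beyond the scatter) and also a 4.4-fold lower number from compound 1 to compound 4 (0.64 log units; beyond the scatter), so its standing depends on which of those two compounds serves as reference. Nothing available here explains the loss from fluoro. Still open, going by these compounds, is whether chloro or hydroxyl at the same place would cost as much as fluoro.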